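USP7 inhibitors: a sulfonamide in place of an amine

The compounds below may be only part of what the source reports. "The series", "measured", "known", "first", "only" and "open" are said of these compounds alone.

Compounds measured so far:
compound 1, `Cn1nc2c(=O)n(CC3(O)CCN(Cc4ccc(-c5n[nH]c(=O)o5)cc4Cl)CC3)cnc2c1-c1ccc(CN)cc1`, 171 nM
compound 2, `Cn1nc2c(=O)n(CC3(O)CCN(Cc4ccc(-c5ccco5)cc4Cl)CC3)cnc2c1-c1ccc(C2(N)CC2)cc1`, 66.1 nM

In an assay on isolated protein for inhibition of ubiquitin carboxyl-terminal hydrolase 7 (Homo sapiens), with stated times of 30 min and 2 h (on this read-out lower numbers stand for stronger inhibition and higher numbers for weaker inhibition), compound 2 gives the lower of the two numbers, and compound 1 gives the higher one; that gap lies beyond the scatter. Compound 3, `Cn1nc2c(=O)n(CC3(O)CCN(Cc4ccc(-c5ccco5)cc4Cl)CC3)cnc2c1-c1ccc(CNS(C)(=O)=O)cc1`, differs from compound 2 by (methanesulfonamido)methyl in place of 1-aminocyclopropyl on an aromatic carbon. Among the measured compounds shown here, no pair of measured compounds shows this change alone, so its effect is untested here. The step from compound 2 to compound 3 in this assay is expected to be moderate and toward a higher number, a 2.3-fold higher number from compound 2 to compound 3 (0.36 log units; beyond the scatter). Compound 3 is therefore estimated at 150 nM, within a range from 50 nM to 500 nM.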

Compound 3, half-maximal inhibitory concentration: 65.3 nM
Beside the measured number, compound 3's estimate is 2.3-fold (0.36 log units) above it; measured number inside the range.
By their numbers in this assay, from the lowest: compounds 3 and 2 (each within the scatter of the next); then compound 1.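

In this assay, (methanesulfonamido)methyl in place of 1-aminocyclopropyl, on an aromatic carbon para to a large group, gives a 1.0-fold lower number from compound 2 to compound 3 (0.01 log units; within the scatter), a step within the scatter. This position therefore takes two quite different groups without a measurable change: the ring of carbon goes and the sulfonamide enters, and the number holds. The earlier compounds shown here could not show this, as they differ in more than one place. Going by these compounds, whether a carboxylic acid or an acetamidomethyl group at this position would read the same remains open. Nothing shown explains why these two groups read alike.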